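Cyclohexyl for Naphthalenyl: Expected Permeability of Compound 3

A few compounds are considered here, and "the series" means these few. Any claim that something is new, unique, unknown or untested is made for them only; others in the source may bear on it.

Measured compounds:
compound 1, `FC(F)(F)c1ccc(-c2ccc3c(NCCCNCc4ccco4)ccnc3c2)cc1` — 237 10^-6 cm/s
compound 2, `c1coc(CNCCCNc2ccnc3cc(-c4cccc5ccccc45)ccc23)c1` — 237 10^-6 cm/s

In an ADME assay for permeability, using PAMPA, with a stated time of 30 min, at pH 7.4 (a lower number here means that the compound crosses the layer more slowly, a higher number that the compound crosses the layer faster), compound 1 gives 237 10^-6 cm/s, and compound 2 gives 237 10^-6 cm/s. For the measured compounds named here, the one measured step, no change at the digits printed from compound 1 to compound 2 (within the scatter), carried naphthalen-1-yl in place of 4-(trifluoromethyl)phenyl on an aromatic carbon and left the read-out unchanged within the scatter. Compound 2 therefore stands level with compound 1 at the digits shown; its nearest neighbour is compound 1, with no change at the digits shown.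

Compound 3, `c1coc(CNCCCNc2ccnc3cc(C4CCCCC4)ccc23)c1`, differs from compound 2 by cyclohexyl in place of naphthalen-1-yl on an aromatic carbon. Going by the values given here, no measured step exchanges an aromatic ring for a non-aromatic one at this carbon, so the only step that bears on the change is the flat one from compound 1 to compound 2, which replaced one aromatic group by another at the same place. On that basis the expected step in this assay is a 1.1-fold lower number from compound 2 to compound 3 (0.05 log units; within the scatter), with no direction favoured beyond the scatter. Compound 3 is accordingly estimated at 210 10^-6 cm/s, within a range from 110 10^-6 cm/s to 330 10^-6 cm/s.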

Compound 3, apparent permeability: 23 10^-6 cm/s
For compound 3 the middle estimate is 9.1-fold (0.96 log units) above the measured one, and the stated range ends above it.
By their numbers in this assay, from the lowest: compound 3; then compounds 1 and 2 (each within the scatter of the next).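

In this assay the aromatic carbon of the shared core, meta to a fused ring and para to a fused ring, proves far from indifferent to the group it carries: cyclohexyl in place of naphthalen-1-yl gives a 10-fold lower number from compound 2 to compound 3 (1.01 log units; beyond the scatter) and cyclohexyl in place of 4-(trifluoromethyl)phenyl gives a 10-fold lower number from compound 1 to compound 3 (1.01 log units; beyond the scatter) at this same carbon. The flat step between compound 1 and compound 2 therefore described only an exchange of one aromatic group for another, and the large fall appears with the only non-aromatic ring among the three compounds, so the two aromatic groups now stand together against cyclohexyl. Nothing measured alongside these read-outs accounts for the size of this fall.

The step from compound 2 changes several things at once, since two six-membered aromatic rings of carbon only and 10 heavy atoms leave while one six-membered non-aromatic ring of carbon only and 6 heavy atoms enter, so the compounds shown cannot say which of these changes matters. On these data alone, a plain phenyl ring at this carbon would keep the aromatic character in a single ring, while a piperidine ring or an open hexyl chain would test other non-aromatic groups, and how any of these would read here remains open.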